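This account rests on a few compounds, and the source may have more. Where it says the series, first, only, none or still open, it means among the compounds named here.

Measured compounds:
compound 1 `CCc1noc(-c2ccc(C(C)=O)cc2)n1` — in a functional assay on HaCaT cells (Homo sapiens), read by MTT assay, with a stated time of 48 h (a lower number here means a stronger inhibitor, a higher number a weaker inhibitor), compound 1 gives > 30000 nM, a limit of the assay.
compound 2 `CCc1noc(-c2cc(C(C)=O)cs2)n1` — in this assay compound 2 gives > 30000 nM, likewise a limit.
compound 3 `CCc1noc(-c2ccccc2)n1` — in this assay compound 3 gives > 30000 nM, again a limit.

The difference between the cores of compound 1 and compound 2 is not broken down here. From compound 1 to compound 3 the change is hydrogen in place of acetyl on an aromatic carbon and gives a step that the two limits leave unreadable from compound 1 to compound 3, both values sitting at the limit of > 30000 nM in this assay, at which 3 of the 3 values shown sit. Compound 4 `CCc1noc(-c2cccs2)n1` is not yet measured; against compound 2 it shows (hydrogen in place of acetyl on an aromatic carbon). The places differ: in compound 1 the acetyl sits on a six-membered aromatic ring of carbon only, para to a group of 7 heavy atoms; in compound 2 on a five-membered aromatic ring with 1 sulfur, two ring bonds from the ring sulfur. So this is the same kind of change, not the same change. In this assay the step from compound 2 to compound 4 is expected to be a step that the limit leaves unreadable from compound 2 to compound 4, set beside a step that the two limits leave unreadable from compound 1 to compound 3, an expectation resting on compound 1 and compound 3 both standing at the limit of > 30000 nM in this assay, at which 3 of the 3 values shown sit. Compound 4 is therefore estimated at 40000 nM, most probably reported again only as a limit.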

Compound 4, half-maximal inhibitory concentration: > 30000 nM
Compound 4: no number, only a limit (the forecaster's own chance of this, stated with the estimate: 90%); the middle value is on the limit's open side.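

No step can be read from compound 2 to compound 4, as both values are limits: the limit of > 30000 nM in this assay, at which 4 of the 4 values shown sit.

With no number among them, the compounds shown leave open whether hydrogen in place of acetyl has any effect in this assay.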